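One Methyl Added Twice: Estimating Compound 4

The source may hold more compounds than are shown below. What is called first, only, known or untested is meant among the compounds shown, and "the series" means these compounds.

Measured so far in a functional assay on A-375 cells (Homo sapiens) for cytotoxicity, read by MTT assay, with a stated time of 72 h; a lower number here means a stronger inhibitor, a higher number a weaker inhibitor:
- compound 1 `N/C(=N\NC(=S)N1CCCCCC1)c1ccccn1` gives 740 nM
- compound 2 `N/C(=N\NC(=S)N1CCCCC1)c1ccccn1` gives 680 nM
- compound 3 `Cc1cccc(/C(N)=N/NC(=S)N2CCCCC2)n1` gives 1000 nM

Compound 1 and compound 2 share a common arrangement, but the difference between their two cores is not broken down here; their values in this assay lie within the scatter of each other. From compound 2 to compound 3 the change is methyl in place of hydrogen on an aromatic carbon, and it produced a 1.5-fold higher number from compound 2 to compound 3 (0.17 log units; within the scatter).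

Compound 4 `Cc1cccc(/C(N)=N/NC(=S)N2CCCCCC2)n1` has not yet been measured. It differs from compound 1 by methyl in place of hydrogen on an aromatic carbon, the same change that was made from compound 2 to compound 3, since the two descriptions of the place agree word for word. Within the data shown here, with only one earlier instance of the change, the expectation for compound 4 rests on that step alone. Compound 4 is therefore expected to show a step of a 1.5-fold higher number from compound 1 to compound 4 (0.17 log units; within the scatter) from compound 1, matching a 1.5-fold higher number from compound 2 to compound 3 (0.17 log units; within the scatter) in size. On that basis compound 4 is estimated at 1100 nM in this assay, with an expected range from 550 nM to 2200 nM.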

Compound 4, half-maximal inhibitory concentration: 1800 nM
Beside the measured number, compound 4's estimate is 1.6-fold (0.21 log units) below it; measured number inside the range.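

In this assay the swap of hydrogen for methyl on an aromatic carbon next to the ring nitrogen gave a 2.4-fold higher number from compound 1 to compound 4 (0.39 log units; beyond the scatter) and so carried the number beyond the scatter on the core of compound 1. Set beside the earlier step on the core of compound 2, the change points the same way on both cores, and the two sizes cannot be told apart: the same change on two cores in this assay, a 1.5-fold higher number (0.17 log units; within the scatter) from compound 2 to compound 3 and a 2.4-fold higher number (0.39 log units; beyond the scatter) from compound 1 to compound 4, 1.7-fold (0.22 log units) apart, within the scatter of two such steps. This supports carrying the change between these two cores as a rise of similar size, but two instances do not establish a fixed step, and they show nothing about any other core or assay.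

The compounds shown leave open whether an ethyl group, a chlorine atom or an amine at the same place would move the number in the same way as methyl. They also leave open whether methyl on another carbon of the aromatic ring would repeat either step.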